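The source may report more compounds than this note shows. Statements on the series, on what has been measured and on what is new or still open speak of the compounds shown alone.

Working notes on the series. Two compounds have numbers in a functional assay on CHO cells for agonist activity at Free fatty acid receptor 1 (Homo sapiens), read by FLIPR and calcium flux; on this read-out higher numbers stand for an effect only at larger amounts of compound and lower numbers for an effect already at smaller amounts. Compound 1 `O=C(O)COc1ccc(NCc2cccc(-c3ccccc3Cl)c2)cc1F` gives 19.3 nM in this assay, and compound 2 `Cc1cc(OCCCS(C)(=O)=O)ccc1-c1cccc(CNc2ccc(OCC(=O)O)c(F)c2)c1` gives 45.6 nM. Compound 1 therefore holds the lower of the two numbers, and the gap between the two lies beyond the scatter of this assay.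

Compound 3 `Cc1noc(C)c1-c1cccc(CNc2ccc(OCC(=O)O)c(F)c2)c1` has not yet been measured in this assay. It keeps the shared core of compound 1 and differs in one place: 3,5-dimethyl-1,2-oxazol-4-yl in place of 2-chlorophenyl on an aromatic carbon; the change sits on an aromatic carbon of a six-membered aromatic ring of carbon only, meta to a large group. Among the measured compounds shown here, no measured pair in this set tracks this kind of exchange, so the size of the step rests on the two numbers alone. A step upward in this assay of modest size is expected, possibly just beyond the scatter, since compound 1 gives 19.3 nM and nothing measured here argues for a number lower than that. The step from compound 1 to compound 3 is expected to be a 2.1-fold higher number from compound 1 to compound 3 (0.32 log units; beyond the scatter). Compound 3 is accordingly estimated at 40 nM, with a range from 12 nM to 130 nM.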

Compound 3, half-maximal effective concentration: 225 nM
The estimate for compound 3 lay 5.6-fold (0.75 log units) below the measured number; the whole stated range lies below it.
By their numbers in this assay, from the lowest: compound 1; then compound 2; then compound 3.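

In this assay, putting 3,5-dimethyl-1,2-oxazol-4-yl in place of 2-chlorophenyl on this aromatic carbon gives a 12-fold higher number from compound 1 to compound 3 (1.07 log units; beyond the scatter), so the number at this place depends strongly on which ring is attached. Both groups have 7 heavy atoms and no net charge, so an equal heavy-atom count does not preserve the number; the exchange instead replaces a six-membered aromatic ring of carbon only and its chlorine with a five-membered aromatic ring with 2 hetero atoms and 2 hydrogen-bond acceptors. No measured property of these compounds bears on the step, and the size of the step stands here without an explanation.

The compounds shown leave open which part of the exchange carries the step, since ring size, ring hetero atoms, the methyl groups and the loss of chlorine all change together. Unsubstituted phenyl, 2-methylphenyl, 2-fluorophenyl or pyridin-3-yl on the same aromatic carbon would separate these parts, and an unmethylated 1,2-oxazol-4-yl would show what the two methyl groups contribute.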